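Methoxy in Place of Hydrogen: Expected Effect in Compound 4

The compounds below may be only part of what the source reports. "The series", "measured", "known", "first", "only" and "open" are said of these compounds alone.

Of the compounds shown here, three built on one shared core have been tested in a functional assay on MCF7 cells (Homo sapiens) for cytotoxicity, read by MTT assay, with a stated time of 2 days, tested at 0.1 uM; a lower number here means a stronger effect, a higher number a weaker effect of the compound at the concentration tested. Compound 1 `CC(=O)c1cc(-c2ccccc2)cc2cc(-c3ccccc3)[nH]c12` gives 99.3% in this assay. Compound 2 `COc1ccc(-c2cc(C(C)=O)c3[nH]c(-c4ccc(OC)cc4)cc3c2)cc1`, which carries a methoxy group on each of its two outer rings, gives 96.5%. Compound 3 `CC(=O)c1cc(/C=C/c2ccc(F)cc2)cc2cc(-c3ccccc3)[nH]c12` gives 89.7%. Compound 3 thus holds the lowest of the three numbers, but its distance to compound 2 and to compound 1 lies within the scatter, so no ordering among the three can be claimed. Among the measured compounds shown here, the one measured step, a number 9.6 percentage points lower from compound 1 to compound 3 (within the scatter), concerns the replacement of phenyl by 2-(4-fluorophenyl)ethenyl and stayed within the scatter.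

Compound 4 `COc1ccc(-c2cc3cc(/C=C/c4ccc(F)cc4)cc(C(C)=O)c3[nH]2)cc1` differs from compound 3 by methoxy in place of hydrogen on an aromatic carbon. For the measured compounds named here, no measured step isolates this change. Compound 1 and compound 2 differ by two methoxy groups at once, and on that pair compound 1 gives 99.3% while compound 2 gives 96.5%, a gap that is small. All three measured values sit close to full viability, and nothing among them suggests that a single methoxy group should move the number far. Compound 4 is therefore expected to give 89% in this assay, with a range from 79% to 99%. The estimated step of a number 0.7 percentage points lower from compound 3 to compound 4 (within the scatter) is expected to remain within the scatter.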

Compound 4, a percentage reported as activity, at one concentration (the size of the read-out at that concentration, not a potency): 97.2%
Compound 4: the middle estimate sits 8.2 percentage points below what was measured; measured number inside the range.
By their numbers in this assay, from the lowest: compounds 3, 2, 4 and 1 (each within the scatter of the next).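

The change of phenyl to 4-methoxyphenyl now has a step of its own: in this assay it reads a number 7.5 percentage points higher from compound 3 to compound 4 (within the scatter), so with the 2-(4-fluorophenyl)ethenyl group in place, a single methoxy on this ring has no effect that can be told from the scatter. The second step, a number 0.7 percentage points higher from compound 2 to compound 4 (within the scatter), shows that 2-(4-fluorophenyl)ethenyl in place of 4-methoxyphenyl also stays within the scatter when a 4-methoxyphenyl group remains elsewhere on the shared core. Every step measured among these compounds thus lies within the scatter, and neither methoxy nor 2-(4-fluorophenyl)ethenyl separates one compound from another at the single concentration tested. Nothing available explains why the numbers stay so close.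

On these data alone, it remains open whether an amine, a carboxylic acid or a longer chain such as butoxy at this same place, para to a large group, would give a step beyond the scatter. The compounds shown also leave open whether methoxy in place of hydrogen would still fall within the scatter at a higher concentration, where the numbers might sit further from full viability.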